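Ether to thioether on a weak melanocortin-4 ligand

The source may report more compounds than this note shows. Statements on the series, on what has been measured and on what is new or still open speak of the compounds shown alone.

Compound 1 `COc1cc(Cl)ccc1C[C@@H](C)C(=O)N1CCN(c2ccc(C)cc2[C@@H](N)CC(C)C)CC1`: 8.1 nM
Compound 2 `CC(C)C[C@H](N)c1cc(C(F)(F)F)ccc1N1CCN(C(=O)COc2cccc(Cl)c2Cl)CC1`: 2500 nM
Compound 3 `Cc1ccc(N2CCN(C(=O)[C@H](C)Cc3ccc(Cl)cc3F)CC2)c([C@@H](N)CC(C)C)c1`: 20 nM

All three values come from an assay on HEK293 cells for displacement of a labelled ligand from Melanocortin receptor 4 (Homo sapiens); a higher number here means a weaker inhibitor, a lower number a stronger inhibitor. Compound 2 stands at the weak end of this small set: in this assay compound 2 gives 2500 nM, well beyond the scatter from compound 3 and further still from compound 1. Among the compounds with values here, the only measured step, a 2.5-fold higher number from compound 1 to compound 3 (0.39 log units; beyond the scatter), concerns a different part of the shared core and says nothing directly about the amide-linked side.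

Compound 4 `CC(C)C[C@H](N)c1cc(C(F)(F)F)ccc1N1CCN(C(=O)CSc2ccc(Cl)cc2Cl)CC1` differs from compound 2 in one place: (2,4-dichlorophenyl)sulfanyl in place of 2,3-dichlorophenoxy on a saturated chain carbon bound to a carbonyl carbon. Within the data shown here, no measured pair shows what such a swap does here, so the account has nothing to lean on except compound 2 itself. The expectation is therefore that compound 4 stays close to compound 2, with a 1.3-fold lower number from compound 2 to compound 4 (0.10 log units; within the scatter) as the estimated step, in no direction beyond the scatter with any confidence. In this assay compound 4 is estimated at 2000 nM, with a range from 500 nM to 8000 nM.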

Compound 4, inhibition constant: 1500 nM
Estimate against measurement, compound 4: 1.3-fold (0.12 log units) above; low and high end bracket the measured number.
By their numbers in this assay, from the lowest: compound 1; then compound 3; then compounds 4 and 2 (each within the scatter of the next).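

In this assay the exchange on a saturated chain carbon bound to a carbonyl carbon gives a 1.7-fold lower number from compound 2 to compound 4 (0.22 log units; within the scatter) and so this position tolerates (2,4-dichlorophenyl)sulfanyl in place of 2,3-dichlorophenoxy without a readable shift in the number. Within the data shown here, the change is a double one, since sulfur replaces oxygen and the chlorine numbering moves as well, and the single step cannot separate these two parts, which may act alone or offset each other. No evidence at hand bears on why the two groups read alike.

On these data alone, what a 2,4-dichlorophenoxy group or a 2,3-dichlorophenylsulfanyl group would give on its own remains open, and either would divide the step into its parts. Also open, as far as these compounds go, is whether this side tolerates a more different group, such as an amine or carboxylic acid on the aromatic ring, or a longer chain before the sulfur.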